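Swapping Fluoro for Bromo on the Anilide Ring

This account rests on a few compounds, and the source may have more. Where it says the series, first, only, none or still open, it means among the compounds named here.

Compound 1, `CN(C)C(=O)c1cc2cnc(Nc3ccc(NC(=O)C4(C(=O)Nc5ccc(F)cc5)CC4)cc3)nc2n1C1CCCC1`: 102%
Compound 2, `CN(C)C(=O)c1cc2cnc(Nc3ccc(NC(=O)C4(C(=O)Nc5cccc(F)c5)CC4)cc3)nc2n1C1CCCC1`: 98.8%

Of the compounds shown here, two have been measured in a functional assay on NCI-H460 cells (Homo sapiens) for inhibition, read by CCK-8 assay, with a stated time of 72 h, tested at 10 uM; a lower number here means less inhibition of growth, a higher number more inhibition of growth at the concentration tested. In this assay compound 1 gives 102%, and compound 2 gives 98.8%. Going by the values given here, compound 1 holds the higher of the two numbers, but its only neighbour, compound 2, lies within the scatter, since a number 3.2 percentage points lower from compound 1 to compound 2 (within the scatter); the two cannot be told apart. The unmeasured compound 3, `CN(C)C(=O)c1cc2cnc(Nc3ccc(NC(=O)C4(C(=O)Nc5ccc(Br)cc5)CC4)cc3)nc2n1C1CCCC1`, differs from compound 1 in a single place: bromo in place of fluoro on an aromatic carbon. Among the compounds with values here, only one measured step exists, the move of fluoro from one ring position to another, and that step, a number 3.2 percentage points lower from compound 1 to compound 2 (within the scatter), concerns the position of the halogen, not its identity. Within the data shown here, no measured pair exchanges fluoro for bromo, so the present change is not covered directly; the one step available merely shows that a small alteration on this ring left the number within the scatter. Because compound 1 already reaches 102%, little room remains upward, and the expected step of a number 3 percentage points lower from compound 1 to compound 3 (within the scatter) is none beyond the scatter. Compound 3 is therefore estimated at 99%, between 88% and 105%.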

Compound 3, percent growth inhibition at one concentration: 96.4%
Compound 3: middle estimate off by 2.6 percentage points, on the high side; measured number inside the range.
By their numbers in this assay, from the lowest: compounds 3, 2 and 1 (each within the scatter of the next).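

Exchanging the halogen itself, not just moving it around the ring, gives a number 5.6 percentage points lower from compound 1 to compound 3 (within the scatter) in this assay, so at this position, para to a large group, fluoro and bromo cannot be told apart in this read-out. The comparison with the compound carrying its fluoro elsewhere on the ring agrees, giving a number 2.4 percentage points lower from compound 2 to compound 3 (within the scatter), so the 4-fluorophenyl, 3-fluorophenyl and 4-bromophenyl versions all stand level within the scatter, and the ring has now tolerated both a change of halogen position and a change of halogen identity without a measurable effect. No independent measurement bears on this result.

The compounds shown leave open whether a group of a different kind on this ring, such as a methoxy group, an amine or a carboxylic acid, would move the number beyond the scatter, since all three compounds carry a single halogen. They also leave open whether these three would separate at a lower concentration, where a read-out taken at one fixed dose could show differences that are hidden here.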